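Working notes: pyridin-3-yl in place of 4-methoxyphenyl

The source may hold more compounds than are shown below. What is called first, only, known or untested is meant among the compounds shown, and "the series" means these compounds.

Compound 1 `COc1ccc(-c2ccc(CNCCNc3ccnc4cc(Cl)ccc34)s2)cc1`: 3130 nM
Compound 2 `CC(=O)Nc1ccc(-c2ccc(CNCCCNc3ccnc4cc(Cl)ccc34)s2)cc1`: 2080 nM

Both values come from an ADME assay on PBMC cells (Homo sapiens) for cytotoxicity, read by MTT assay, with a stated time of 48 h; on this read-out higher numbers stand for weaker inhibition and lower numbers for stronger inhibition. Among the compounds with values here, the series has only these two measured values so far, and they lie within the scatter of each other. Compound 1, at 3130 nM, therefore sits level with compound 2 on the present numbers. Within the data shown here, no pair of measured compounds differing in one place is available, so the data give no measured step to carry over.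

Compound 3 `Clc1ccc2c(NCCNCc3ccc(-c4cccnc4)s3)ccnc2c1` is still to be measured in this assay. Its structure has pyridin-3-yl in place of 4-methoxyphenyl on an aromatic carbon. The exchange lies on an aromatic carbon of a five-membered aromatic ring with 1 sulfur, and the series holds no direct measure of its effect. The expectation therefore rests on compound 1 at 3130 nM as the starting point, and no step beyond the scatter is foreseen, with no firm direction. The expected change is a 1.1-fold higher number from compound 1 to compound 3 (0.05 log units; within the scatter). For compound 3 the estimated value is 3500 nM, with an expected range from 1500 nM to 9000 nM.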

Compound 3, half-maximal inhibitory concentration: 16400 nM
Estimate against measurement, compound 3: 4.7-fold (0.67 log units) below; the whole stated range lies below it.
By their numbers in this assay, from the lowest: compounds 2 and 1 (each within the scatter of the next); then compound 3.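

In this assay, pyridin-3-yl in place of 4-methoxyphenyl, on an aromatic carbon next to the ring sulfur, gives a 5.2-fold higher number from compound 1 to compound 3 (0.72 log units; beyond the scatter), so the number at this position depends on which aromatic group it carries, which compounds 1 and 2 could not show because they differ in more than one place. The step moves toward weaker inhibition, although the two groups have the same counts of hydrogen-bond donors and acceptors and neither carries a net charge; what differs is the heavy-atom count, the nitrogen in the ring and the loss of the methoxy group. No measurement at hand bears on why the number rises.

The compounds shown do not separate the ring nitrogen from the loss of the methoxy group: plain phenyl at this position would stand between the two, and pyridin-4-yl would test where the nitrogen sits. On these data alone, whether the exchange carries the same step with the chain of compound 2 also remains open, as does its size with an amine or a carboxylic acid on the outer ring.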